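The source may report more compounds than this note shows. Statements on the series, on what has been measured and on what is new or still open speak of the compounds shown alone.

Measured in an assay on lysate for inhibition of 6-phosphofructo-2-kinase/fructose-2,6-bisphosphatase 3 (Homo sapiens), with stated times of 0.5 min and 45 min; a higher number here means a weaker inhibitor, a lower number a stronger inhibitor:
compound 1 `Cn1cc(CNC(=O)c2ccncc2Nc2cc(-c3ccc4ccn(C)c4c3)c3nccnc3c2)cn1` — 75900 nM
compound 2 `CC(=O)N1CCC(NC(=O)c2ccncc2Nc2cc(-c3ccc4ccn(C)c4c3)c3nccnc3c2)CC1` — 31300 nM
compound 3 `Cn1ccc2ccc(-c3cc(Nc4cnccc4C(=O)NCC4COCCN4)cc4nccnc34)cc21` — 41700 nM

Compound 3 stands second highest of the three numbers in this assay; its gap to compound 2 is within the scatter, and its gap to compound 1 is within the scatter as well, so no ordering among the three is secure. The change to compound 4 `CC(=O)N1CCOC(CNC(=O)c2ccncc2Nc2cc(-c3ccc4ccn(C)c4c3)c3nccnc3c2)C1` is 4-acetylmorpholin-2-yl in place of morpholin-3-yl on a saturated chain carbon bound to an amide-type nitrogen. Within the data shown here, two measured steps bear on this. a 1.8-fold lower number from compound 1 to compound 3 (0.26 log units; within the scatter) exchanged the group on the same saturated chain carbon and stayed within the scatter. a 1.3-fold higher number from compound 2 to compound 3 (0.12 log units; within the scatter) set an acetyl-bearing ring against the morpholine chain and also stayed within the scatter. Only a 2.4-fold lower number from compound 1 to compound 2 (0.38 log units; beyond the scatter) went beyond the scatter, and it is modest. Compound 4 carries an acetyl-bearing ring, as compound 2 does. The step expected in this assay is therefore a 1.2-fold lower number from compound 3 to compound 4 (0.08 log units; within the scatter), small and without a secure direction. Compound 4 is estimated at 35000 nM, with a range of 15000 nM to 80000 nM.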

Compound 4, half-maximal inhibitory concentration: > 100000 nM
Compound 4: a limit, no number; the forecaster's own chance of this, stated with the estimate: 10%; middle value at least 2.8-fold (0.45 log units) from the limit.
By their numbers in this assay, from the lowest: compounds 2, 3 and 1 (each within the scatter of the next, the first and the last beyond it). At a limit, above all of these: compound 4.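

In this assay compound 4 gives a limit and not a number, > 100000 nM. On the saturated chain carbon bound to an amide-type nitrogen, 4-acetylmorpholin-2-yl in place of morpholin-3-yl gives an at least 2.3-fold higher number from compound 3 to compound 4 (0.37 log units; beyond the scatter), and set against the 1-acetylpiperidin-4-yl of compound 2 the change gives an at least 3.1-fold higher number from compound 2 to compound 4 (0.50 log units; beyond the scatter), so carrying an acetyl-bearing ring does not by itself hold the number near that of compound 2. The remaining step reads an at least 1.3-fold higher number from compound 1 to compound 4 (0.11 log units; that floor lies within the scatter), so that floor leaves the order of these two unsettled.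

The change alters both the acetyl on the ring nitrogen and the ring's attachment, and the compounds shown do not separate the two. A plain morpholin-2-yl or a 4-acetylmorpholin-3-yl would divide them, while a simple amine or a carboxylic acid on the same chain remains an open comparison.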